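A few compounds are considered here, and "the series" means these few. Any claim that something is new, unique, unknown or untested is made for them only; others in the source may bear on it.

Compound 1, `CC1=C(C(=O)OC(C)(C)C)C(c2ccsc2)NC(=O)N1`, gives 1% in an assay on membranes from HeLa cells for displacement of a labelled ligand from adenosine receptor A3 (Homo sapiens), read by scintillation counting, with a stated time of 180 min, tested at 1 uM; a higher number here means more inhibition at the concentration tested (going by the name of the read-out), a lower number less inhibition.
Compound 2, `CC1=C(C(=O)OC(C)(C)C)C(c2ccoc2)NC(=O)N1C`, gives 12% in this assay.
Compound 3, `CCCOC(=O)C1=C(C)N(C)C(=O)NC1c1ccsc1`, gives 11% in this assay.

All three measured compounds share one core and were tested at a single concentration in this assay, so each number is simply how much of the labelled ligand was displaced there, not a potency. Compound 3 sits close to compound 2, and even the gap to compound 1 is within the usual scatter of this measurement, so the three numbers cannot be told apart with confidence; none of them shows more than slight inhibition.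

Compound 4, `CC1=C(C(=O)OC(C)(C)C)C(c2ccsc2)NC(=O)N1C`, has not yet been measured in this assay. Its structure differs from compound 3 in one place: tert-butyl in place of propyl on an oxygen next to a carbonyl group. Among the measured compounds shown here, no measured pair in this set shows what swapping one alkyl group for another on that oxygen does to the read-out, so there is nothing to build a directional expectation on. Given that every compound so far reads low and within the scatter of each other, the step of a number 1 percentage points lower from compound 3 to compound 4 (within the scatter) is expected to be none beyond the scatter. Compound 4 is therefore estimated at 10%, with a range from 0% to 25%.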

Compound 4, a percentage reported as inhibition, at one concentration (the size of the read-out at that concentration, not a potency): 14%
Estimate against measurement, compound 4: 4 percentage points below; the measured number falls inside the stated range.
By their numbers in this assay, from the lowest: compounds 1, 3, 2 and 4 (each within the scatter of the next, the first and the last beyond it).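

In this assay, tert-butyl in place of propyl on an oxygen next to a carbonyl group gives a number 3 percentage points higher from compound 3 to compound 4 (within the scatter), and thiophen-3-yl in place of furan-3-yl on a saturated ring carbon gives a number 2 percentage points higher from compound 2 to compound 4 (within the scatter), so at this stage neither swap has a readable effect on the inhibition. Among the compounds shown here, the one change that can be read is methyl in place of hydrogen on an amide-type nitrogen in a ring, which gives a number 13 percentage points higher from compound 1 to compound 4 (beyond the scatter), a modest step that rests on this single pair of compounds, both carrying tert-butyl and thiophen-3-yl. Nothing shown here explains why this methyl group matters while the other two swaps do not.

On these data alone, whether the methyl step holds with propyl or furan-3-yl in place remains open, since compound 2 and compound 3 each carry that methyl but appear without a partner bearing hydrogen there. Also open, as far as these compounds go, is how the read-out would respond to a longer chain on that ring nitrogen, or to an amine or a carboxylic acid in place of the tert-butyl group on that oxygen.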